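Removing the carboxy group from compound 1

The source may report more compounds than this note shows. Statements on the series, on what has been measured and on what is new or still open speak of the compounds shown alone.

Measured so far in an ADME assay on Raji cells (Homo sapiens) for cytotoxicity, with a stated time of 72 h; on this read-out higher numbers stand for an effect only at larger amounts of compound and lower numbers for an effect already at smaller amounts:
Compound 1 `Cc1ccc(-c2nc3ccccc3s2)cc1NC(=O)c1cc([N+](=O)[O-])c(N2CCC(C(=O)O)CC2)cc1Cl` gives the limit > 25000 nM only.
Compound 2 `O=C(Nc1nc2ccc(F)cc2s1)c1cc([N+](=O)[O-])ccc1Cl` gives the limit > 27000 nM only.
Compound 3 `O=C(Nc1nc(-c2ccc(Cl)cc2)cs1)c1cc([N+](=O)[O-])ccc1Cl` gives 12000 nM as a measured number.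

Compound 1 has no exact value on this read-out, only a limit. Among the compounds with values here, compound 2 also has only a limit, so compound 3 is the sole compound with an exact value.

The next compound to be tested is compound 4 `Cc1ccc(-c2nc3ccccc3s2)cc1NC(=O)c1cc([N+](=O)[O-])c(N2CCCCC2)cc1Cl`. It differs from compound 1 in one place: hydrogen in place of carboxy on a saturated ring carbon. In words, hydrogen replaces carboxy on a saturated ring carbon, turning 4-carboxypiperidin-1-yl into piperidin-1-yl.

Within the data shown here, no two measured compounds differ in just one place, so the effect of this change has not been measured directly. The expectation therefore rests on thin evidence. Among the measured compounds shown here, the only exact value comes from compound 3 (12000 nM), which serves as a rough guide to where a measurable result might fall. A modest shift towards an effect at smaller amounts of compound is expected, and the estimated step is an at least 2.0-fold lower number from compound 1 to compound 4 (0.31 log units; beyond the scatter). Compound 4 may still return only a limit. For compound 4 the estimated value is 12000 nM, with an expected range from 3000 nM to 30000 nM.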

Compound 4, half-maximal effective concentration: > 25000 nM
Compound 4 gave a limit, no number; the forecaster's own chance of this, stated with the estimate: 40%; at least 2.0-fold (0.31 log units) between middle value and limit.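

Compound 1 and compound 4 both return only a limit, so no step can be read from compound 1 to compound 4: the limit of > 25000 nM in this assay, at which 2 of the 4 values shown sit. The compounds shown leave open whether hydrogen in place of carboxy on the saturated ring carbon changes the result in this assay at all, and in which direction.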